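A few compounds are considered here, and "the series" means these few. Any claim that something is new, unique, unknown or untested is made for them only; others in the source may bear on it.

In a functional assay on MOLT-4 cells (Homo sapiens) for antiproliferative activity, read by MTT assay, with a stated time of 48 h (a higher number here means a weaker inhibitor, a lower number a stronger inhibitor), compound 1 `O=C(CCCCCCn1cc(Nc2ncc(Cl)c(Nc3cccc(Cl)c3)n2)cn1)NO` gives 130 nM, compound 2 `O=C(CCCCCn1cc(Nc2ncc(Cl)c(Nc3cccc(Cl)c3)n2)cn1)NO` gives 80 nM and compound 3 `O=C(CCCCCCn1cc(Nc2ncc(Cl)c(Nc3ccc(F)cc3)n2)cn1)NO` gives 220 nM. Compound 3 carries the highest of these three numbers. Its gap to compound 2 lies beyond the scatter, and its closest comparison is a 1.7-fold higher number from compound 1 to compound 3 (0.23 log units; within the scatter). Compound 4 `O=C(CCCCCn1cc(Nc2ncc(Cl)c(Nc3ccc(F)cc3)n2)cn1)NO` has not yet been measured and departs from compound 3 in one place: hydroxycarbamoyl in place of (hydroxycarbamoyl)methyl on a saturated chain carbon, five bonds along the chain from an aromatic nitrogen. Hydroxycarbamoyl stands in place of (hydroxycarbamoyl)methyl on a saturated chain carbon, five bonds along the chain from an aromatic nitrogen. The same change has been measured once, in the other aryl series, as a 1.6-fold lower number from compound 1 to compound 2 (0.21 log units; within the scatter). That single precedent is small and gives only weak support for a direction, so at most a modest move toward a lower number in this assay is expected, with no step beyond the scatter. The expected change is a 1.6-fold lower number from compound 3 to compound 4 (0.21 log units; within the scatter). The estimate for compound 4 is 135 nM, with an expected range of 70 nM to 260 nM.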

Compound 4, half-maximal inhibitory concentration: 120 nM
Compound 4: middle estimate off by 1.1-fold (0.05 log units), on the high side; measured number inside the range.
By their numbers in this assay, from the lowest: compounds 2, 4, 1 and 3 (each within the scatter of the next, the first and the last beyond it).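

In this assay, the change from (hydroxycarbamoyl)methyl to hydroxycarbamoyl now has a second reading, a 1.8-fold lower number from compound 3 to compound 4 (0.26 log units; within the scatter), and it agrees with the first: the same change on two cores in this assay, a 1.6-fold lower number (0.21 log units; within the scatter) from compound 1 to compound 2 and a 1.8-fold lower number (0.26 log units; within the scatter) from compound 3 to compound 4, 1.1-fold (0.05 log units) apart, within the scatter of two such steps. The change from 3-chlorophenyl to 4-fluorophenyl can likewise be read on the second chain, a 1.5-fold higher number from compound 2 to compound 4 (0.18 log units; within the scatter), and the two readings again agree: the same change on two cores in this assay, a 1.7-fold higher number (0.23 log units; within the scatter) from compound 1 to compound 3 and a 1.5-fold higher number (0.18 log units; within the scatter) from compound 2 to compound 4, 1.1-fold (0.05 log units) apart, within the scatter of two such steps. Across these four compounds, neither change depends on the other, although every single step stays within the scatter.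

The compounds shown leave open how a longer chain or a carboxylic acid in place of hydroxycarbamoyl would read in this assay. They also leave open whether the aryl step follows the halogen or its place on the ring, which 4-chlorophenyl could help to separate.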